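Cyclohexyl to 2,2,2-trifluoroethyl: compound 1 to compound 3

The source may report more compounds than this note shows. Statements on the series, on what has been measured and on what is new or still open speak of the compounds shown alone.

Working notes on the series. In a functional assay on HeLa cells (Homo sapiens) for inhibition (a higher number here means a weaker inhibitor of growth, a lower number a stronger inhibitor of growth), compound 1 (`O=C(OC1CCCCC1)c1ccsc1NC(=O)[C@@H]1CCCN1`) gives 92.8 ug/mL, and compound 2 (`C=CCOC(=O)c1ccsc1NC(=O)[C@@H]1CCCN1`) gives 94.9 ug/mL. Among the measured compounds shown here, only these two numbers are available, and they lie within the scatter of each other, so compound 1 stands level with its sole measured neighbour.

Compound 3 (`O=C(OCC(F)(F)F)c1ccsc1NC(=O)[C@@H]1CCCN1`) has not yet been measured. The change from compound 1 is 2,2,2-trifluoroethyl in place of cyclohexyl on an oxygen next to a carbonyl group.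

For the measured compounds named here, one measured step bears on this place, allyl in place of cyclohexyl on the same oxygen: a 1.0-fold higher number from compound 1 to compound 2 (0.01 log units; within the scatter). That replacement left the number in this assay unchanged within the scatter. Going by the values given here, no compound with fluorine in this place has been measured, and a single step is thin support, so the range is kept wide.

The expected step is a 1.0-fold higher number from compound 1 to compound 3 (0.01 log units; within the scatter), with no direction expected beyond the scatter. For compound 3 the estimated value is 95 ug/mL, with an expected range of 55 ug/mL to 160 ug/mL.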

Compound 3, concentration for 50% growth inhibition: 109 ug/mL
The estimate for compound 3 lay 1.1-fold (0.06 log units) below the measured number; low and high end bracket the measured number.
By their numbers in this assay, from the lowest: compounds 1, 2 and 3 (each within the scatter of the next).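

In this assay the step to 2,2,2-trifluoroethyl on an oxygen next to a carbonyl group is a 1.2-fold higher number from compound 1 to compound 3 (0.07 log units; within the scatter) and the step to trifluoromethyl in place of vinyl is a 1.1-fold higher number from compound 2 to compound 3 (0.06 log units; within the scatter) so compound 3 stands level with both earlier compounds. The range of groups tolerated at this place without a change beyond the scatter now extends from cyclohexyl and allyl to a group carrying fluorine, and none of compounds 1, 2 and 3 goes against this. No measurement at hand explains why the numbers stay level across these three groups.

The compounds shown leave open whether any group on this oxygen can move the number beyond the scatter, for instance a chain ending in an amine or a carboxylic acid, or simply a longer chain. Equally open, on these data alone, is how the number in this assay responds to a change elsewhere in the core of compound 1, such as a methyl group in place of the amide hydrogen.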